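The source may hold more compounds than are shown below. What is called first, only, known or untested is meant among the compounds shown, and "the series" means these compounds.

Measured in a physicochemical assay for solubility; a lower number here means a less soluble compound, a higher number a more soluble compound:
- Compound 1 `O=C(c1ccc(C(F)(F)F)cc1)N1CCC(NS(=O)(=O)c2cc(S(=O)(=O)c3ccccc3)ccc2C(F)(F)F)CC1`: 6300 nM
- Compound 2 `N#Cc1cccc(S(=O)(=O)N2CCC(NS(=O)(=O)c3cc(S(=O)(=O)c4ccccc4)ccc3C(F)(F)F)CC2)c1`: 6300 nM
- Compound 3 `CC(C)(C)OC(=O)N1CCC[C@@H]1C(=O)N1CCC(NS(=O)(=O)c2cc(S(=O)(=O)c3ccccc3)ccc2C(F)(F)F)CC1`: 25000 nM

Compound 3, at 25000 nM, stands highest of the three in this assay, and both other compounds lie beyond the scatter from it. Compound 4 `O=C([C@H]1CCNC1)N1CCC(NS(=O)(=O)c2cc(S(=O)(=O)c3ccccc3)ccc2C(F)(F)F)CC1` has not yet been measured. It carries pyrrolidin-3-yl in place of 1-(tert-butoxycarbonyl)pyrrolidin-2-yl on a carbonyl carbon.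

Among the measured compounds shown here, two measured steps bear on this change. The closer one is a 4.0-fold higher number from compound 1 to compound 3 (0.60 log units; beyond the scatter), a modest step at the same carbonyl carbon. The other, no change at the digits printed from compound 1 to compound 2 (within the scatter), replaces the whole group on an amine nitrogen in a ring. Neither step tests the loss of the tert-butoxycarbonyl group directly, so the evidence is thin. Going by the modest size of a 4.0-fold higher number from compound 1 to compound 3 (0.60 log units; beyond the scatter), a small upward step is expected, no larger than that one, and it may stay within the scatter. The expected step is a 2.0-fold higher number from compound 3 to compound 4 (0.30 log units; within the scatter). For compound 4 the estimated value is 50000 nM, with an expected range of 12500 nM to 100000 nM.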

Compound 4, solubility: 25000 nM
For compound 4 the middle estimate is 2.0-fold (0.30 log units) above the measured one, within the range that was stated.
By their numbers in this assay, from the lowest: compounds 1 and 2 (each within the scatter of the next); then compounds 3 and 4 (each within the scatter of the next).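

In this assay the exchange of 1-(tert-butoxycarbonyl)pyrrolidin-2-yl for pyrrolidin-3-yl on the carbonyl carbon gives no change at the digits printed from compound 3 to compound 4 (within the scatter) even though the entering group has fewer heavy atoms than the leaving one, so the tert-butoxycarbonyl group is not required for this level. The aromatic comparisons now extend to the unprotected ring: pyrrolidin-3-yl in place of 4-(trifluoromethyl)phenyl gives a 4.0-fold higher number from compound 1 to compound 4 (0.60 log units; beyond the scatter) and (pyrrolidin-3-yl)carbonyl in place of (3-cyanophenyl)sulfonyl gives a 4.0-fold higher number from compound 2 to compound 4 (0.60 log units; beyond the scatter) on the amine nitrogen in a ring. No measurement shown accounts for these steps.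

On these data alone, whether the ring nitrogen of pyrrolidin-3-yl matters stays open, since a cyclopentyl group, an open-chain amine or a carboxylic acid on this carbonyl carbon could read differently. The step from compound 3 to compound 4 also changes the attachment point together with the loss of the tert-butoxycarbonyl group, and the compounds shown do not separate the two.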